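Alkyl imine variation on the shared core, compound 3 to 4

The source may hold more compounds than are shown below. What is called first, only, known or untested is meant among the compounds shown, and "the series" means these compounds.

Compound 3 `C/C(=N\C(C)C)c1c(O)c2ccccc2oc1=O` stands only at a limit: in an assay on isolated protein for inhibition of myosin-2 (Bos taurus), read by spectrophotometry, with a stated time of 24 min (a higher number here means a weaker inhibitor, a lower number a stronger inhibitor), compound 3 gives >= 100000 nM, which is a limit of the assay and not a number. The two other measured compounds sit at the same limit. Compound 1 `C/C(=N\CC1CCCCC1)c1c(O)c2ccccc2[nH]c1=O` in this assay gives >= 100000 nM, a limit. Compound 2 `CCC(C)/N=C(\C)c1c(O)c2ccccc2[nH]c1=O` in this assay gives >= 100000 nM, also a limit. Among the compounds with values here, the one measured step, a step that the two limits leave unreadable from compound 1 to compound 2, has no readable size because the limit of >= 100000 nM in this assay, at which 3 of the 3 values shown sit, holds both of its ends, and that limit is the only evidence across the set.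

Compound 4 `C/C(=N\CC(C)C)c1c(O)c2ccccc2oc1=O` differs from compound 3 as isobutyl in place of isopropyl on a double-bonded nitrogen. Within the data shown here, no measured step covers this change, and the step that the two limits leave unreadable from compound 1 to compound 2, the only other change on a double-bonded nitrogen, gives no direction or size. Given (the limit of >= 100000 nM in this assay, at which 3 of the 3 values shown sit), compound 4 is expected to remain at the limit as well, so the expected step in this assay is a number no higher from compound 3 to compound 4 (the limit leaves the size open), nothing beyond the scatter. Compound 4 is estimated at 100000 nM, within 30000 nM to 300000 nM, most likely reported as a limit only.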

Compound 4, half-maximal inhibitory concentration: 34000 nM
Estimate against measurement, compound 4: 2.9-fold (0.47 log units) above; the measured number falls inside the stated range.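

Isobutyl in place of isopropyl on a double-bonded nitrogen gives an at least 2.9-fold lower number from compound 3 to compound 4 (0.46 log units; beyond the scatter) in this assay and is the first change in the set with a readable direction. Compound 3 stands at a limit and not a number, so the step has a lower bound and no exact size. A small change in the chain on this nitrogen is enough to bring compound 4 off the limit that holds the other compounds: the limit of >= 100000 nM in this assay, at which 3 of the 4 values shown sit.

As far as these compounds go, the step from compound 1 to compound 2 still cannot be read, and it remains open whether isobutyl would give a readable number on the core of compound 1. Also open, from the compounds shown here alone, is whether the number falls further with a longer chain such as n-pentyl, or changes with an amine or a carboxylic acid at the end of the chain.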